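Series notes: varying the group on the ring nitrogen

This account rests on a few compounds, and the source may have more. Where it says the series, first, only, none or still open, it means among the compounds named here.

Of the compounds shown here, two have numbers so far. Compound 1 `Cc1nc(S(C)(=O)=O)ccc1Oc1ncnc(OC2CCN(C(=O)OC(C)(C)CF)CC2)c1F` in a functional assay on isolated protein for inhibition of Glucose-dependent insulinotropic receptor (Rattus norvegicus), read by HTRF and cAMP accumulation (a lower number here means a smaller maximal response, a higher number a larger maximal response), gives 95%. Compound 2 `Cc1nc(S(C)(=O)=O)ccc1Oc1ncnc(OC2CCN(C(=O)SC3(C)CC3)CC2)c1F` in this assay gives 77%. Within the data shown here, the single measured step, a number 18 percentage points lower from compound 1 to compound 2 (beyond the scatter), puts a group of 5 heavy atoms (4 carbon, 1 sulfur; one three-membered non-aromatic ring of carbon only) in place of a group of 6 heavy atoms (4 carbon, 1 oxygen, 1 fluorine; no ring), on a carbonyl carbon. Compound 2 thus stands lowest of the two numbers, with compound 1 the nearest and higher by that step.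

Compound 3 `Cc1nc(S(C)(=O)=O)ccc1Oc1ncnc(OC2CCN(C(=S)OC(C)C)CC2)c1F` is not yet measured. It differs from compound 2 by a group of 6 heavy atoms (4 carbon, 1 oxygen, 1 sulfur; no ring) in place of a group of 7 heavy atoms (5 carbon, 1 oxygen, 1 sulfur; one three-membered non-aromatic ring of carbon only), on an amine nitrogen in a ring. Among the measured compounds shown here, the one measured step bears on this change, since it sits at the same place on the amine nitrogen in a ring, and it was of modest size. As the entering group of compound 3 again carries an oxygen and no ring, as in compound 1, a modest rise is expected in this assay. For compound 3 the estimate is 87%, within 72% to 100%. The expected step is a number 10 percentage points higher from compound 2 to compound 3 (within the scatter).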

Compound 3, largest response reached (reported as efficacy), in percent of the reference or control that the assay uses: 47%
Compound 3: the middle estimate sits 40 percentage points above what was measured; the measured number lies below the stated range.
By their numbers in this assay, from the lowest: compound 3; then compound 2; then compound 1.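

In this assay, among these compounds, the group on the amine nitrogen in a ring moves the maximal response further than the first pair showed: the step of a number 30 percentage points lower from compound 2 to compound 3 (beyond the scatter) is followed by the step of a number 48 percentage points lower from compound 1 to compound 3 (beyond the scatter) as the widest gap so far. Compound 1 and compound 3 both carry a group with oxygen and no ring, yet they stand far apart, so those two features alone do not keep the response high at this position. Each new step changes several features of the group at once, including the thiocarbonyl of compound 3 in place of the carbonyl of compound 1, and no measurement on hand accounts for the fall or assigns it to any one of them.

The compounds shown leave open whether the fall follows the thiocarbonyl itself or the carbon part of the group attached through oxygen. Also open, on these data alone, is where an amide or a urea on the amine nitrogen in a ring would stand in this assay relative to the carbonyl group of compound 1 and the thiocarbonyl group of compound 3.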